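Cyclohexyl Thiocarbamate: Expected Inhibition From Three Measured Analogues

The source may report more compounds than this note shows. Statements on the series, on what has been measured and on what is new or still open speak of the compounds shown alone.

Measured compounds:
Compound 1, `CC(C)c1cccc(C(C)C)c1OC(=O)NC(=O)OC(c1ccccc1)c1ccccc1`: 350 nM
Compound 2, `CCCCCCCCOC(=O)NC(=O)Oc1c(C(C)C)cccc1C(C)C`: 250 nM
Compound 3, `CC(C)c1cccc(C(C)C)c1OC(=O)NC(=O)SCc1ccc(Cl)cc1`: 160 nM

All three share the same core, and each was tested in an assay on microsomes from intestine for inhibition of acyl-CoA:cholesterol acyltransferase (Oryctolagus cuniculus); a higher number here means a weaker inhibitor, a lower number a stronger inhibitor. Compound 3 has the lowest number of the three; the gap to compound 2 is within the scatter, so the two cannot be ordered, while the gap to compound 1 lies beyond it.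

Compound 4, `CC(C)c1cccc(C(C)C)c1OC(=O)NC(=O)SC1CCCCC1`, has not yet been measured. It differs from compound 3 in one place: cyclohexyl in place of 4-chlorobenzyl on a sulfur. Among the measured compounds shown here, the only measured step that touches this part of the molecule is a 1.6-fold lower number from compound 2 to compound 3 (0.19 log units; within the scatter), and that step changed both the atom attached to the carbonyl carbon and the group on it at once, so it speaks only indirectly to the present change, in which the sulfur stays and only the group on it is exchanged. For the measured compounds named here, no measured pair shows two different groups on a sulfur. With this little to go on, the expectation is a step of no more than the scatter in this assay, with the direction open.

Compound 4 is therefore estimated at 250 nM, within a range from 100 nM to 650 nM, which means an expected step of a 1.6-fold higher number from compound 3 to compound 4 (0.19 log units; within the scatter).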

Compound 4, half-maximal inhibitory concentration: 97 nM
Beside the measured number, compound 4's estimate is 2.6-fold (0.41 log units) above it, and the stated range ends above it.
By their numbers in this assay, from the lowest: compounds 4, 3, 2 and 1 (each within the scatter of the next, the first and the last beyond it).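

In this assay, among the compounds shown here, this is the first pair with two different groups on the sulfur, and exchanging 4-chlorobenzyl for cyclohexyl gives a 1.6-fold lower number from compound 3 to compound 4 (0.22 log units; within the scatter). An aromatic ring bearing chlorine and a non-aromatic ring of carbon only can therefore each sit on this sulfur with no difference that can be told from the scatter of the measurement. For the compounds shown here, the wider change from octyloxy to cyclohexylsulfanyl on the carbonyl carbon gives a 2.6-fold lower number from compound 2 to compound 4 (0.41 log units; beyond the scatter), a modest step that is the first one in this set beyond the scatter at this carbonyl carbon, though it exchanges the attached atom and the group together, and nothing available explains either step.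

As far as these compounds go, what the sulfur contributes on its own remains open, since separating it from the group it carries would take a matched pair such as cyclohexyloxy against cyclohexylsulfanyl, or octyloxy against octylsulfanyl. From the compounds shown here alone, it is also open how the sulfur position would respond to a group unlike these carbon-based ones, such as an amine or a carboxylic acid.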